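Methoxy for chloro on the 4-chlorobenzyl group

The compounds below may be only part of what the source reports. "The series", "measured", "known", "first", "only" and "open" are said of these compounds alone.

For the measured compounds named here, in a functional assay on HepG2 cells (Homo sapiens) for antiproliferative activity, read by MTT assay, with a stated time of 48 h (a lower number here means a stronger inhibitor, a higher number a weaker inhibitor), compound 1 `Clc1ccc(CNc2ccc3ncnc(Nc4cccc(Br)c4)c3c2)cc1` gives 920 nM and compound 2 `Clc1ccc(CNc2ccc3ncnc(Nc4cccc(Cl)c4)c3c2)cc1` gives 1780 nM as the only two numbers so far. On these numbers compound 2 cannot be told apart from compound 1. Going by the values given here, the one measured step is a 1.9-fold higher number from compound 1 to compound 2 (0.29 log units; within the scatter) for chloro in place of bromo on an aromatic carbon, and it leaves the 4-chlorobenzyl group untouched.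

Compound 3 `COc1ccc(CNc2ccc3ncnc(Nc4cccc(Cl)c4)c3c2)cc1` carries methoxy in place of chloro on an aromatic carbon, para to a large group, giving 4-methoxybenzyl: methoxy in place of chloro on an aromatic carbon is the full count of the change. Among the compounds with values here, no measured step covers this place, so no size or direction can be read from the data, and no step beyond the scatter is expected in this assay for now. The estimated step is a 1.0-fold higher number from compound 2 to compound 3 (0.00 log units; within the scatter) and remains a rough expectation. Compound 3 is expected near 1800 nM with an estimated range from 700 nM to 5000 nM on present data.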

Compound 3, half-maximal inhibitory concentration: 5260 nM
Compound 3: middle estimate off by 2.9-fold (0.47 log units), on the low side; the measured number lies above the stated range.
By their numbers in this assay, from the lowest: compounds 1 and 2 (each within the scatter of the next); then compound 3.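

In this assay, for the compounds shown here, the 4-chlorobenzyl position proves sensitive to what it carries: methoxy in place of chloro gives a 3.0-fold higher number from compound 2 to compound 3 (0.47 log units; beyond the scatter), the first step to lie beyond the scatter. The earlier step, a 1.9-fold higher number from compound 1 to compound 2 (0.29 log units; within the scatter), was at a different place and showed nothing about this one. Going from 4-chlorobenzyl to 4-methoxybenzyl thus lowers antiproliferative activity on this single pair, and nothing at hand accounts for the step.

From the compounds shown here alone, whether the loss is particular to methoxy stays open, since an amine, a hydroxyl or a methyl on the same aromatic carbon would show whether other groups behave alike. Going by these compounds, it is also open whether the same step appears with bromo in place of chloro at the other place, as in compound 1.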